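This account rests on a few compounds, and the source may have more. Where it says the series, first, only, none or still open, it means among the compounds named here.

Working notes on the series around the shared core of compound 1 `COc1ccc2c(=O)c(/C=C/C(=O)Nc3cccc(C)c3)coc2c1`, read in a functional assay on Huh-7 cells (Homo sapiens) for inhibition, read by MTT assay, with a stated time of 48 h; a lower number here means a stronger inhibitor, a higher number a weaker inhibitor. Compound 1 gives 15500 nM, and compound 3 `COc1ccc2c(=O)c(/C=C/C(=O)Nc3cc(C)ccc3C)coc2c1` gives 11100 nM. These two sit close together: a 1.4-fold lower number from compound 1 to compound 3 (0.15 log units; within the scatter). Compound 2 `COc1ccc2c(=O)c(/C=C/C(=O)Nc3cccc(Cl)c3)coc2c1` gives > 100000 nM, which is a limit and not a number. It therefore stands at the limit of > 100000 nM in this assay, at which 1 of the 3 values shown sits.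

Compound 4 `COc1ccc2c(=O)c(/C=C/C(=O)NCc3ccccc3F)coc2c1` is not yet measured. It carries 2-fluorobenzyl in place of 3-chlorophenyl on an amide-type nitrogen.

Among the compounds with values here, two measured steps bear on this change: an at least 6.4-fold higher number from compound 1 to compound 2 (0.80 log units; beyond the scatter) and an at least 9.0-fold lower number from compound 2 to compound 3 (0.95 log units; beyond the scatter). The second changes the same place, and the first shows the cost of the chloro group in this series. Neither step tests a benzyl group, so only part of that size is expected to carry over, towards a lower number in this assay. The expected step is an at least 2.8-fold lower number from compound 2 to compound 4 (0.45 log units; beyond the scatter). The estimate for compound 4 is 35000 nM, with an expected range from 10000 nM to 100000 nM.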

Compound 4, half-maximal inhibitory concentration: 8450 nM
Estimate against measurement, compound 4: 4.1-fold (0.62 log units) above; measured number below the stated range.
By their numbers in this assay, from the lowest: compounds 4, 3 and 1 (each within the scatter of the next). At a limit, above all of these: compound 2.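

In this assay, moving from an aryl group directly on the amide-type nitrogen to 2-fluorobenzyl gives an at least 11-fold lower number from compound 2 to compound 4 (1.07 log units; beyond the scatter), so this place also accepts a benzyl group. With a 1.3-fold lower number from compound 3 to compound 4 (0.12 log units; within the scatter) and a 1.8-fold lower number from compound 1 to compound 4 (0.26 log units; within the scatter), both within the scatter, compound 4 reads level with the two methyl-bearing compounds, and its fluorine shows that a halogen on the aromatic ring does not by itself lead to the result for compound 2. That result remains a limit and not a number: the limit of > 100000 nM in this assay, at which 1 of the 4 values shown sits.

From the compounds shown here alone, it stays open whether the step follows the added carbon, the change from chlorine to fluorine, or the different placing of the halogen; plain benzyl and 3-chlorobenzyl would separate these. Going by these compounds, how a longer chain such as 2-phenylethyl, or an amine on the aromatic ring, would read at this place is also open.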